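The source may hold more compounds than are shown below. What is called first, only, known or untested is meant among the compounds shown, and "the series" means these compounds.

Compound 1 `CCN(CC)c1cc2[nH]c(C3CCCCC3)nc2cc1NC(=O)c1cnccn1` — > 100 ug/mL
Compound 2 `CCOCCOC(=O)Nc1cc2nc(C3CCCCC3)[nH]c2cc1N1CCCC1` — > 100 ug/mL

Of the compounds shown here, two have so far been measured in an ADME assay on Vero cells (Chlorocebus sabaeus) for cytotoxicity, read by resazurin assay, with a stated time of 3 days; a lower number here means a stronger inhibitor, a higher number a weaker inhibitor. Compound 1 gives > 100 ug/mL, which is a limit of the assay rather than a number. Compound 2 likewise gives > 100 ug/mL, again a limit. Compound 1 therefore stands at the limit of > 100 ug/mL in this assay, at which 2 of the 2 values shown sit, and how the two measured compounds sit relative to each other cannot be told from these values. Among the compounds with values here, no step between measured compounds can be drawn.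

The next compound, compound 3 `CCN(CC)c1cc2[nH]c(C3CCCCC3)nc2cc1NC(=O)c1ccc(C)cc1`, differs from compound 1 by 4-methylphenyl in place of pyrazin-2-yl on a carbonyl carbon. With both measured values sitting at the same limit, nothing in these data points toward a step beyond the usual scatter, and compound 3 is expected to remain near that limit, with an expected step of a number no higher from compound 1 to compound 3 (the limit leaves the size open) of essentially none. Compound 3 is accordingly estimated at 100 ug/mL, within a range from 50 ug/mL to 200 ug/mL.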

Compound 3, half-maximal inhibitory concentration: > 100 ug/mL
Compound 3: no number, only a limit; the forecaster's own chance of this, stated with the estimate: 75%; the middle value lies on the limit itself.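

In this assay, within the data shown here, compound 3 gives > 100 ug/mL, which is a limit and not a number, so no step from compound 1 to compound 3 can be read. The compounds shown leave open how their actual values compare, since all share one limit: the limit of > 100 ug/mL in this assay, at which 3 of the 3 values shown sit.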